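A few compounds are considered here, and "the series" means these few. Any claim that something is new, unique, unknown or untested is made for them only; others in the source may bear on it.

Measured compounds:
- compound 1 `COC(=O)c1ccc(NCc2cncn2Cc2ccccc2C(C)(C)C)cc1-c1ccccc1`, a toxicity assay on NIH3T3 cells (Mus musculus) for cytotoxicity, read by resazurin assay; on this read-out lower numbers stand for an effect already at smaller amounts and higher numbers for an effect only at larger amounts of compound: "not determined" (no result reported)
- compound 2 `O=C(OC1CCCCC1)c1ccc(NCc2cncn2Cc2ccc(-c3ccccc3)cc2)cc1-c1ccccc1`, this assay: > 10000 nM
- compound 3 `COC(=O)c1ccc(NCc2cncn2Cc2cccc(OC)c2)cc1-c1ccccc1`, this assay: "not determined" (no result reported)

Only compound 2 has a reported result, and that result is a limit of the assay rather than a number: compound 2 gives > 10000 nM, meaning (the limit of > 10000 nM in this assay, at which 1 of the 3 values shown sits). For the measured compounds named here, compound 1 and compound 3 carry no result at all, so no step between measured compounds can be compared. The unmeasured compound 4 `CN(C)C(=O)c1ccc(NCc2cncn2Cc2ccc(-c3ccccc3)cc2)cc1-c1ccccc1` differs from compound 2 in one place: dimethylamino in place of cyclohexyloxy on a carbonyl carbon. Going by the values given here, with no measured step to lean on, compound 4 is expected to stay near the same limit, the step from compound 2 to compound 4 being estimated at a step that the limit leaves unreadable from compound 2 to compound 4, not clearly beyond the scatter in either direction. Compound 4 is therefore estimated at 15000 nM, within 5000 nM to 50000 nM.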

Compound 4, half-maximal effective concentration: > 1000 nM
Compound 4: no number, only a limit; the forecaster's own chance of this, stated with the estimate: 70%; the middle value does not contradict the limit.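

For the compounds shown here, compound 2 and compound 4 each carry only a limit of the assay in this assay, and no step between them can be read. The compounds shown leave open at what concentration either one would affect these cells.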